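The source may report more compounds than this note shows. Statements on the series, on what has been measured and on what is new or still open speak of the compounds shown alone.

Working notes on the series in an ADME assay on MDBK cells (Bos taurus) for cytotoxicity; a lower number here means that less compound is tolerated, a higher number that more compound is tolerated. Compound 1 `Fc1cccc(F)c1Cn1c(-c2c(F)cccc2F)nc2cnccc21` reads > 100000 nM, which is a limit of the assay and not a number. Compound 2 `Fc1cccc(F)c1Cn1c(-c2c(F)cccc2F)nc2ccncc21` gives a measured 99000 nM. Compound 3 `Fc1cccc(F)c1Cn1cccc2nc(-c3c(F)cccc3F)nc1-2` reads > 100000 nM, likewise a limit only. Compound 3 therefore sits at the limit of > 100000 nM in this assay, at which 2 of the 3 values shown sit, with no exact value to anchor the next step. Compound 4 `Cc1ccn(Cc2c(F)cccc2F)c2nc(-c3c(F)cccc3F)nc1-2` differs from it as follows: methyl in place of hydrogen on an aromatic carbon, para to a 2,6-difluorobenzyl group. For the measured compounds named here, no measured pair isolates this change, so no step beyond the scatter is expected in this assay. The expected change is a number no higher from compound 3 to compound 4 (the limit leaves the size open). Compound 4 is estimated at 100000 nM, with an expected range from 50000 nM to 200000 nM.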

Compound 4, half-maximal cytotoxic concentration: > 100000 nM
Compound 4: only a limit was reported (the forecaster's own chance of this, stated with the estimate: 70%); the middle value lies on the limit itself.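

Compound 3 and compound 4 both read only as limits in this assay, so no step can be read for methyl in place of hydrogen. The compounds shown leave open whether this methyl shifts the tolerated concentration at all.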